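Working notes: aryl changes on the aromatic nitrogen

A few compounds are considered here, and "the series" means these few. Any claim that something is new, unique, unknown or untested is made for them only; others in the source may bear on it.

Measured so far in a functional assay on PC-12 cells (Rattus norvegicus) for cytotoxicity, read by MTT assay, with stated times of 2 h and 24 h, tested at 5 uM; on this read-out lower numbers stand for a weaker effect and higher numbers for a stronger effect at the one concentration tested:
compound 1, `CCc1ccc(-n2nc(-c3ccc(C(F)(F)F)cc3O)nc2-c2ccccc2O)cc1`, 95.4%
compound 2, `Oc1cc(C(F)(F)F)ccc1-c1nc(-c2ccccc2O)n(-c2ccc(F)cc2)n1`, 86.7%
compound 3, `N#Cc1ccc(-n2nc(-c3ccc(C(F)(F)F)cc3O)nc2-c2ccccc2O)cc1`, 86.8%

Compound 3 stands second highest of the three numbers in this assay. Its nearest neighbour is compound 2, and the two differ by a number 0.1 percentage points higher from compound 2 to compound 3 (within the scatter). The furthest is compound 1, and the gap there is a number 8.6 percentage points lower from compound 1 to compound 3 (within the scatter). Compound 1 and compound 2 themselves are separated by a number 8.7 percentage points lower from compound 1 to compound 2 (within the scatter). All three steps change only the group on the aromatic nitrogen, and none of them moves the read-out beyond the scatter.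

The next compound, compound 4, `Oc1cc(C(F)(F)F)ccc1-c1nc(-c2ccccc2O)n(-c2ccc(Cl)cc2Cl)n1`, carries the change (2,4-dichlorophenyl in place of 4-cyanophenyl on an aromatic nitrogen). Within the data shown here, the steps that bear on it are those that swapped the group on the same aromatic nitrogen: a number 8.6 percentage points lower from compound 1 to compound 3 (within the scatter) and a number 0.1 percentage points higher from compound 2 to compound 3 (within the scatter). Both were small. No step beyond the scatter is therefore expected in this assay for the move to compound 4.

For compound 4 the estimate is 88%, with a range from 74% to 98%. The step that this estimate means is expected to be a number 1.2 percentage points higher from compound 3 to compound 4 (within the scatter).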

Compound 4, a percentage reported as activity, at one concentration (the size of the read-out at that concentration, not a potency): 86.7%
The estimate for compound 4 lay 1.3 percentage points above the measured number, and the stated range covers the measured number.
By their numbers in this assay, from the lowest: compounds 2, 4, 3 and 1 (each within the scatter of the next).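

Among these compounds, the 2,4-dichlorophenyl group brings chlorine to this aromatic nitrogen for the first time, and in this assay the change gives a number 0.1 percentage points lower from compound 3 to compound 4 (within the scatter). Against the other two aryl groups, the same entering group gives no change at the digits printed from compound 2 to compound 4 (within the scatter) and a number 8.7 percentage points lower from compound 1 to compound 4 (within the scatter), so the swap of 4-fluorophenyl or 4-ethylphenyl for 2,4-dichlorophenyl also stays inside the usual spread of repeats. All four aryl groups at this position, with ethyl, fluoro, cyano or two chlorines on the phenyl ring, therefore remain within the scatter of one another, and no information is available to account for this flat picture.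

The compounds shown all keep a phenyl ring on this nitrogen and are read at one concentration, so they give no potency and no view of how far the position tolerates change. A carboxylic acid or an amine on that phenyl ring, or a longer alkyl chain such as hexyl in place of the ring, would test whether the read-out at this position moves beyond the scatter at all.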